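This account rests on a few compounds, and the source may have more. Where it says the series, first, only, none or still open, it means among the compounds named here.

Within the data shown here, in a functional assay on HepG2 cells (Homo sapiens) for inhibition, read by MTT assay, with a stated time of 48 h (a lower number here means a stronger inhibitor, a higher number a weaker inhibitor), compound 1 `COc1cc(/C=N/Nc2nc(-c3ccc(Br)cc3)cs2)cc(Br)c1OC` gives 64600 nM, the higher of the two true numbers so far. Compound 3 `COc1cc(/C=N/Nc2nc(-c3ccc(C(F)(F)F)cc3)cs2)cc(Br)c1OC` gives 31200 nM. Compound 2 `COc1cc(/C=N/Nc2nc(-c3ccc(Br)cc3)cs2)c(Br)c(Br)c1OC` gives > 100000 nM, which is a limit of the assay and not a number.

Compound 4 `COc1ccccc1-c1csc(N/N=C/c2cc(Br)c(OC)c(OC)c2)n1` keeps the core of compound 1 but carries 2-methoxyphenyl in place of 4-bromophenyl, on an aromatic carbon of the five-membered ring: 2-methoxyphenyl in place of 4-bromophenyl on an aromatic carbon.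

Two measured steps offer some guidance. Adding a bromo gives an at least 1.5-fold higher number from compound 1 to compound 2 (0.18 log units; that floor lies within the scatter), but this change leaves the 4-bromophenyl group untouched, so it says little here. Replacing the bromo of that group with trifluoromethyl gives a 2.1-fold lower number from compound 1 to compound 3 (0.32 log units; beyond the scatter), a modest step at the same part of the molecule. Among the measured compounds shown here, no measured compound yet carries a methoxy group on this ring, so the direction is uncertain.

A small step is therefore expected, probably no larger than the scatter, and the estimate is a 1.3-fold lower number from compound 1 to compound 4 (0.11 log units; within the scatter). For compound 4 the expected value is 50000 nM, with an estimated range from 20000 nM to 100000 nM.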

Compound 4, half-maximal inhibitory concentration: 82100 nM
The estimate for compound 4 lay 1.6-fold (0.22 log units) below the measured number; low and high end bracket the measured number.
By their numbers in this assay, from the lowest: compound 3; then compounds 1 and 4 (each within the scatter of the next). At a limit, above all of these: compound 2.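

In this assay, among these compounds, replacing the whole aryl group on the five-membered ring gives a 1.3-fold higher number from compound 1 to compound 4 (0.10 log units; within the scatter), so this position accepts 2-methoxyphenyl for 4-bromophenyl with no step that stands out from the scatter. The earlier step at this place changed only the group carried by the phenyl ring, whereas here the bromine leaves altogether and compound 4 still stays level with compound 1, so this bromine is not needed to keep that level. Compound 2 remains a limit of the assay and not a number: the limit of > 100000 nM in this assay, at which 1 of the 4 values shown sits.

As far as these compounds go, it stays open how an amine or a carboxylic acid would behave in place of the methoxy on this ring. From the compounds shown here alone, it is equally open whether a longer chain here, with no phenyl ring at all, would keep the number level with compound 1 or shift it.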